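A few compounds are considered here, and "the series" means these few. Any claim that something is new, unique, unknown or untested is made for them only; others in the source may bear on it.

Measured in a toxicity assay on HepG2 2.2.15 cells (Homo sapiens) for cytotoxicity, read by CellTiter-Glo; on this read-out lower numbers stand for higher toxicity in this test and higher numbers for lower toxicity in this test:
- compound 1 `O=C(Nc1cc(F)c(F)c(F)c1)N1Cc2c(-c3ccc(F)cc3F)cnn2CC1C1CC1`: 32100 nM
- compound 2 `CC1CN(C(=O)Nc2cc(F)c(F)c(F)c2)Cc2c(N3CC(C#N)CC3=O)cnn21`: 115000 nM
- compound 3 `O=C1CC(c2ncc(F)cn2)CN1c1cnn2c1CN(C(=O)Nc1cc(F)c(F)c(F)c1)C(C1CC1)C2`: 115000 nM

Compound 1 stands lowest of the three, and both other compounds lie beyond the usual scatter above it. Compound 4 `O=C1c2ccccc2CN1c1cnn2c1CN(C(=O)Nc1cc(F)c(F)c(F)c1)C(C1CC1)C2` has not yet been measured. It keeps the core of compound 1 but loses the 2,4-difluorophenyl on an aromatic carbon (a group of 10 heavy atoms (8 carbon, 1 nitrogen, 1 oxygen; one five-membered non-aromatic ring with 1 hetero atom, one six-membered aromatic ring of carbon only) in place of a group of 8 heavy atoms (6 carbon, 2 fluorine; one six-membered aromatic ring of carbon only), on an aromatic carbon). Among the compounds with values here, no measured pair isolates this change. The incoming group holds a five-membered non-aromatic ring with 1 hetero atom, as do the corresponding groups in compounds 2 and 3. Compound 3, which gives 115000 nM, also shares the cyclopropyl ring of compound 1. The incoming group still keeps a six-membered aromatic ring of carbon only, as compound 1 does, so only a moderate rise in this assay is expected, probably beyond the scatter. The estimated change is a 2.3-fold higher number from compound 1 to compound 4 (0.37 log units; beyond the scatter). For compound 4 the estimated value is 75000 nM, with an expected range of 28000 nM to 160000 nM.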

Compound 4, half-maximal cytotoxic concentration: 38500 nM
Beside the measured number, compound 4's estimate is 1.9-fold (0.29 log units) above it; measured number inside the range.
By their numbers in this assay, from the lowest: compounds 1 and 4 (each within the scatter of the next); then compounds 2 and 3 (each within the scatter of the next).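

In this assay, exchanging the 2,4-difluorophenyl on this aromatic carbon for the incoming group gives a 1.2-fold higher number from compound 1 to compound 4 (0.08 log units; within the scatter), so the number stays within the scatter even though the new group adds a five-membered non-aromatic ring with 1 hetero atom and a hydrogen-bond acceptor while keeping a six-membered aromatic ring of carbon only. Holding that non-aromatic ring is thus not enough on its own to reach the number of compound 3 at 115000 nM, which carries a different group on that ring. Nothing available explains this result.

What the compounds shown leave open is how an amine or a carboxylic acid on this aromatic carbon would read in this assay. They also leave open whether the same exchange would give so small a step with a methyl in place of the cyclopropyl.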